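From Nitro to Cyano on One Aromatic Carbon

The source may report more compounds than this note shows. Statements on the series, on what has been measured and on what is new or still open speak of the compounds shown alone.

Within the data shown here, in a functional assay on HeLa cells (Homo sapiens) for cytotoxicity, read by MTT assay, with a stated time of 48 h (a higher number here means a weaker inhibitor, a lower number a stronger inhibitor), compound 2 `O=c1ccoc2cc(OCc3cn(Cc4cccc([N+](=O)[O-])c4)nn3)ccc12` gives 17300 nM as the only number so far. Compound 1 `Cc1cccc(Cn2cc(COc3ccc4c(=O)ccoc4c3)nn2)c1` gives > 100000 nM as a limit of the assay and not a number. Compound 3 `N#Cc1cccc(Cn2cc(COc3ccc4c(=O)ccoc4c3)nn2)c1` keeps the shared core and alters the same aromatic carbon. The change is cyano in place of nitro on an aromatic carbon and reads as cyano in place of nitro on an aromatic carbon, meta to a large group. Going by an at least 5.7-fold lower number from compound 1 to compound 2 (0.76 log units; beyond the scatter) as the one measured step at this carbon, with a limit at one end, a modest move back toward a higher number is expected. The estimated change is a 1.7-fold higher number from compound 2 to compound 3 (0.24 log units; within the scatter) in this assay and it may come close to the scatter. For compound 3 the estimate is 30000 nM with an expected range from 9000 nM to 100000 nM in this reading.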

Compound 3, half-maximal inhibitory concentration: > 100000 nM
Compound 3 gave a limit, no number (the forecaster's own chance of this, stated with the estimate: 30%); middle value at least 3.3-fold (0.52 log units) away from the limit.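

In this assay, putting cyano in place of nitro gives an at least 5.7-fold higher number from compound 2 to compound 3 (0.76 log units; beyond the scatter), so the earlier gain over methyl does not extend to this other group at the aromatic carbon, meta to a large group. Of the three groups shown there, only the nitro of compound 2 yields a number. Compound 3 gives > 100000 nM, which is a limit of the assay and not a number, and the step between compound 1 and compound 3 cannot be read, so the position is bounded at one end: the limit of > 100000 nM in this assay, at which 2 of the 3 values shown sit.

On these data alone, it remains open how far compound 1 and compound 3 lie past that limit. Also open, as far as these compounds go, is whether an amine or a carboxylic acid on this carbon would give a number in this assay.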